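Aryl methyl removal: a second instance on a new core

This account rests on a few compounds, and the source may have more. Where it says the series, first, only, none or still open, it means among the compounds named here.

Compound 1 `COc1cc2c(Oc3ccc(NC(=O)c4nn(-c5ccc(C)cc5C)cc(C)c4=O)cc3)ccnc2cc1OCCCCCCC(=O)NO` and compound 2 `COc1cc2c(Oc3ccc(NC(=O)c4nn(-c5ccc(C)cc5)cc(C)c4=O)cc3)ccnc2cc1OCCCCCCC(=O)NO` share one core, while compound 3 `COc1cc2c(Oc3ccc(NC(=O)c4nn(-c5ccccc5C)cc(C)c4=O)cc3F)ccnc2cc1OCCCC(=O)NO` and compound 4 `COc1cc2c(Oc3ccc(NC(=O)c4nn(-c5ccccc5)cc(C)c4=O)cc3F)ccnc2cc1OCCCC(=O)NO` share another; the difference between the two cores is not broken down here. In a functional assay on A549 cells (Homo sapiens) for inhibition, read by MTT assay, with a stated time of 72 h (on this read-out lower numbers stand for stronger inhibition and higher numbers for weaker inhibition), compound 1 gives 1840 nM, and compound 2 gives 160 nM. The change between them is hydrogen in place of methyl on an aromatic carbon, and the step reads a 12-fold lower number from compound 1 to compound 2 (1.06 log units; beyond the scatter). Compound 3 gives 2090 nM in this assay, within the scatter of compound 1 and far from compound 2. The change from compound 3 to compound 4 is hydrogen in place of methyl on an aromatic carbon, the same kind of change as before but not the same: in compound 1 the place is also meta to a methyl group, which is not so in compound 3, and the core differs. The earlier step rests on one pair only. Compound 4 is expected to show a step of a 6.0-fold lower number from compound 3 to compound 4 (0.78 log units; beyond the scatter) in this assay, in the same direction as the earlier step but tempered for the different surroundings. The estimate for compound 4 is 350 nM, with a range from 120 nM to 1100 nM.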

Compound 4, half-maximal inhibitory concentration: 1900 nM
Estimate against measurement, compound 4: 5.4-fold (0.73 log units) below, and the stated range ends below it.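

On the core of compound 3, the swap from 2-methylphenyl to phenyl in this assay gives a 1.1-fold lower number from compound 3 to compound 4 (0.04 log units; within the scatter), so the large step seen on the other core does not carry over. The two steps differ beyond the scatter: the same change on two cores in this assay, a 12-fold lower number (1.06 log units; beyond the scatter) from compound 1 to compound 2 and a 1.1-fold lower number (0.04 log units; within the scatter) from compound 3 to compound 4, 10-fold (1.02 log units) apart, beyond the scatter of two such steps

This shows that the size of the step depends on its surroundings in this series, so a result for this change on one core cannot be taken as a guide to the other. Among these compounds, it does not show which feature of those surroundings matters, as there is only one pair per core and the pairs differ both in the core and in the further methyl group on the aryl ring of the first pair.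

Open, going by these compounds, is whether the step returns on a core that carries only part of the difference between the two cores, for instance the core of compound 3 with a longer chain. Also open, on these data alone, is whether a chlorine atom or a methoxy group in place of the methyl would move the value on the core of compound 3.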